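One Added Methoxy in an Antiproliferative Series

The source may hold more compounds than are shown below. What is called first, only, known or untested is meant among the compounds shown, and "the series" means these compounds.

Compound 1 `COc1cc(C(=O)/C=C\Nc2ccc(-c3nc4cc(OC)c(OC)c(OC)c4s3)cc2)c(Br)c(OC)c1OC`: 15600 nM
Compound 2 `COc1cc(OC)c2sc(-c3ccc(N/C=C\C(=O)c4cc(OC)c(OC)c(OC)c4Br)c(C)c3)nc2c1`: 17300 nM

In a functional assay on MDA-MB-231 cells (Homo sapiens) for antiproliferative activity, read by sulforhodamine B assay, with a stated time of 48 h (a higher number here means a weaker inhibitor, a lower number a stronger inhibitor), compound 2 gives 17300 nM, within the scatter of compound 1 at 15600 nM. Compound 3 `COc1cc(C(=O)/C=C\Nc2ccc(-c3nc4cc(OC)c(OC)c(OC)c4s3)cc2C)c(Br)c(OC)c1OC` derives from compound 2 with methoxy in place of hydrogen on an aromatic carbon, ortho to two methoxy groups (methoxy in place of hydrogen on an aromatic carbon). Compound 1 already carries a methoxy there and gives 15600 nM, so no change beyond the scatter is expected in this assay. The expected step is a 1.1-fold lower number from compound 2 to compound 3 (0.03 log units; within the scatter). For compound 3 the estimated value is 16000 nM, with an expected range of 7000 nM to 36000 nM.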

Compound 3, half-maximal inhibitory concentration: 7300 nM
For compound 3 the middle estimate is 2.2-fold (0.34 log units) above the measured one, within the range that was stated.
By their numbers in this assay, from the lowest: compound 3; then compounds 1 and 2 (each within the scatter of the next).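

In this assay, methoxy in place of hydrogen on an aromatic carbon, ortho to two methoxy groups, gives a 2.4-fold lower number from compound 2 to compound 3 (0.37 log units; beyond the scatter), a modest step beyond the scatter. Methyl in place of hydrogen on an aromatic carbon gives a 2.1-fold lower number from compound 1 to compound 3 (0.33 log units; beyond the scatter), also modest and beyond the scatter, so compound 3, which carries both groups, is the strongest of the three. Nothing available explains either step. The compounds shown leave open whether an amine or a chlorine atom in place of this methoxy would give a similar step, and whether an ethyl group could stand in for the methyl.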